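This account rests on a few compounds, and the source may have more. Where it says the series, first, only, none or still open, it means among the compounds named here.

Measured in an ADME assay on A549 cells (Homo sapiens) for cytotoxicity, read by CellTiter-Glo; on this read-out lower numbers stand for higher toxicity in this test and higher numbers for lower toxicity in this test:
- compound 1 `Cc1c(Cc2ccccc2)c(=O)oc2cc(OCC(O)CNCCCO)ccc12`: 53400 nM
- compound 2 `Cc1c(Cc2ccccc2)c(=O)oc2cc(OCC(O)CNC3CCOCC3)ccc12`: 38200 nM
- compound 3 `Cc1c(Cc2ccccc2)c(=O)oc2cc(OCC(O)CNCc3cccs3)ccc12`: 87300 nM

Compound 3 gives the highest number of the three. Its nearest neighbour is compound 1, with a 1.6-fold higher number from compound 1 to compound 3 (0.21 log units; within the scatter); the furthest is compound 2, with a 2.3-fold higher number from compound 2 to compound 3 (0.36 log units; beyond the scatter). The remaining pair, a 1.4-fold lower number from compound 1 to compound 2 (0.15 log units; within the scatter), is likewise small.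

Compound 4 `Cc1c(Cc2ccccc2)c(=O)oc2cc(OCCCNc3nccs3)ccc12` differs from compound 3 by 2-((1,3-thiazol-2-yl)amino)ethyl in place of 1-hydroxy-2-(((thiophen-2-yl)methyl)amino)ethyl on a saturated chain carbon bound to an oxygen on an aromatic ring. Within the data shown here, none of the measured steps covers this change directly: each of them swaps only the group on the amine nitrogen, and all three remain small, the largest being a 2.3-fold higher number from compound 2 to compound 3 (0.36 log units; beyond the scatter). The change to compound 4 is larger in kind than any of those, touching both the linker and the ring, so the expectation carries more uncertainty, but nothing in the series argues for a large shift in either direction.

Compound 4 is therefore expected to land near the middle of the measured range, with an estimated step of a 1.5-fold lower number from compound 3 to compound 4 (0.16 log units; within the scatter). The estimate for compound 4 in this assay is 60000 nM, with a range from 25000 nM to 130000 nM.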

Compound 4, half-maximal cytotoxic concentration: 50100 nM
For compound 4 the middle estimate is 1.2-fold (0.08 log units) above the measured one; measured number inside the range.
By their numbers in this assay, from the lowest: compounds 2, 4, 1 and 3 (each within the scatter of the next, the first and the last beyond it).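

In this assay, among these compounds, the earlier steps changed only the group on the amine nitrogen, whereas compound 4 changes the whole group on a saturated chain carbon bound to an oxygen on an aromatic ring. Even so, all three new steps stay within the scatter (a 1.7-fold lower number from compound 3 to compound 4 (0.24 log units; within the scatter); a 1.3-fold higher number from compound 2 to compound 4 (0.12 log units; within the scatter); a 1.1-fold lower number from compound 1 to compound 4 (0.03 log units; within the scatter)), so replacing the thiophen-2-yl or other amine-bearing groups and the 1-hydroxy chain with 2-((1,3-thiazol-2-yl)amino)ethyl gives no clear shift from any earlier compound. No evidence is available that explains this result.

Compound 4 changes the chain and the ring together, so their separate contributions remain unresolved. Also open, on these data alone, is whether a carboxylic acid or a longer chain at this place would give a step beyond the scatter.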